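From 3-Bromophenyl to 4-Aminophenyl on the Carbonyl Carbon

The source may hold more compounds than are shown below. What is called first, only, known or untested is meant among the compounds shown, and "the series" means these compounds.

Of the compounds shown here, three with a shared core have been measured; they differ only in the group on the carbonyl carbon. Compound 1 `COc1ccc(/C=C/c2cc(OC)cc(OC)c2/C=C/C(=O)c2ccccc2)cc1` gives 6.8 ug/mL in a functional assay on HepG2 cells (Homo sapiens) for antiproliferative activity, read by MTT assay, with a stated time of 48 h; a higher number here means a weaker inhibitor, a lower number a stronger inhibitor. Compound 2 `COc1ccc(/C=C/c2cc(OC)cc(OC)c2/C=C/C(=O)c2ccc(Cl)c(Cl)c2)cc1` gives 10.8 ug/mL in this assay, and compound 3 `COc1ccc(/C=C/c2cc(OC)cc(OC)c2/C=C/C(=O)c2cccc(Br)c2)cc1` gives 13 ug/mL. Compound 3 has the highest of the three numbers, but its steps from the other two, a 1.9-fold higher number from compound 1 to compound 3 (0.28 log units; within the scatter) and a 1.2-fold higher number from compound 2 to compound 3 (0.08 log units; within the scatter), both lie within the scatter, so the three compounds cannot be ranked on these data.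

Compound 4 `COc1ccc(/C=C/c2cc(OC)cc(OC)c2/C=C/C(=O)c2ccc(N)cc2)cc1` has not yet been measured. It differs from compound 3 as follows: 4-aminophenyl in place of 3-bromophenyl on a carbonyl carbon. Within the data shown here, none of the measured steps introduces an amino group on that ring; the steps that bear on the change are those that vary the group on the carbonyl carbon, namely a 1.6-fold higher number from compound 1 to compound 2 (0.20 log units; within the scatter) and a 1.2-fold higher number from compound 2 to compound 3 (0.08 log units; within the scatter), and both lie within the scatter, as does a 1.9-fold higher number from compound 1 to compound 3 (0.28 log units; within the scatter). Since every variation of this group so far left the number within the scatter, the step to compound 4 is expected to be a 1.3-fold lower number from compound 3 to compound 4 (0.11 log units; within the scatter), with no step beyond the scatter in either direction. Compound 4 is therefore estimated at 10 ug/mL in this assay, with a range from 5 ug/mL to 22 ug/mL.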

Compound 4, half-maximal inhibitory concentration: 7.5 ug/mL
Beside the measured number, compound 4's estimate is 1.3-fold (0.12 log units) above it, within the range that was stated.
By their numbers in this assay, from the lowest: compounds 1, 4, 2 and 3 (each within the scatter of the next).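

In this assay, the 4-aminophenyl group brings a hydrogen-bond donor and a hydrogen-bond acceptor to the carbonyl carbon, features the 3-bromophenyl group does not have, yet the change gives a 1.7-fold lower number from compound 3 to compound 4 (0.24 log units; within the scatter). The comparisons with the other two groups also stay inside that limit, with a 1.4-fold lower number from compound 2 to compound 4 (0.16 log units; within the scatter) and a 1.1-fold higher number from compound 1 to compound 4 (0.04 log units; within the scatter), so adding an amino group to the phenyl ring separates compound 4 from none of the other three compounds. This position has now accepted a nitrogen-bearing substituent as well as halogens without a step beyond the scatter in this assay, though nothing available accounts for that result.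

The step from compound 3 to compound 4 changes both the substituent and its place on the ring, so these compounds cannot show what either change does alone, and a 3-aminophenyl group would be needed to separate them. On these data alone, it also remains open whether a carboxylic acid, a dimethylamino group or a longer chain on this ring would produce a step beyond the scatter.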